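Sulfonyl to carbonyl on the aromatic nitrogen

The source may hold more compounds than are shown below. What is called first, only, known or untested is meant among the compounds shown, and "the series" means these compounds.

Measured so far in a functional assay on HT-29 cells (Homo sapiens) for cytotoxicity, read by resazurin assay, with a stated time of 48 h; on this read-out lower numbers stand for an effect already at smaller amounts and higher numbers for an effect only at larger amounts of compound:
- compound 1 `COc1ccc(S(=O)(=O)Nc2ccc(-c3nc4cc(NS(=O)(=O)c5ccc(OC)cc5)ccc4o3)cc2)cc1` gives 40000 nM
- compound 2 `O=S(=O)(Nc1ccc(-c2nc3cc(NS(=O)(=O)c4ccccc4Cl)ccc3o2)cc1)c1ccccc1Cl` gives 15000 nM
- compound 3 `O=S(=O)(Nc1ccc(-c2nc3cc(NS(=O)(=O)c4cccc(C(F)(F)F)c4)ccc3o2)cc1)c1cccc(C(F)(F)F)c1` gives 19000 nM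

Compound 1 has the highest number of the three, and compound 2 and compound 3 both lie lower by more than the usual scatter. Compound 4 `COc1ccc(S(=O)(=O)Nc2ccc3oc(-c4ccc(NC(=O)c5cccc(C)c5[N+](=O)[O-])cc4)nc3c2)cc1` is still unmeasured. Among the measured compounds shown here, it differs from compound 1 by (3-methyl-2-nitrophenyl)carbonyl in place of (4-methoxyphenyl)sulfonyl on a nitrogen on an aromatic ring and no measured compound carries a carbonyl at that place. For the measured compounds named here, no measured pair differs in one place only, so direct guidance is lacking. The weak guide is that compound 2 at 15000 nM and compound 3 at 19000 nM both carry other groups and both sit lower than compound 1. The reference here is compound 1 with 40000 nM. A moderate step toward lower numbers is therefore expected in this assay and is estimated as a 2.7-fold lower number from compound 1 to compound 4 (0.43 log units; beyond the scatter) with wide uncertainty. The expected value for compound 4 is 15000 nM with 4000 nM to 50000 nM as the estimated range.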

Compound 4, half-maximal effective concentration: 2300 nM
Compound 4: middle estimate off by 6.5-fold (0.81 log units), on the high side, outside the stated range (below it).
By their numbers in this assay, from the lowest: compound 4; then compounds 2 and 3 (each within the scatter of the next); then compound 1.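

In this assay, among the compounds shown here, (3-methyl-2-nitrophenyl)carbonyl in place of (4-methoxyphenyl)sulfonyl on a nitrogen on an aromatic ring gives a 17-fold lower number from compound 1 to compound 4 (1.24 log units; beyond the scatter), the first one-place comparison and a large step beyond the usual scatter. The number at this position therefore responds strongly to the group on this nitrogen, while the second (4-methoxyphenyl)sulfonyl stays unchanged in compound 4. No measurement of any property of the two groups accompanies this step.

The linking sulfonyl and the ring substituents change together, so the shares of the carbonyl, the methyl and the nitro group in the step remain unresolved. As far as these compounds go, a plain benzoyl group, or an amine in place of the nitro group, would help to separate these contributions, and the effect of the same change on the other nitrogen remains open.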